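Dropping a Methoxy Group: Expected Change in Stability

The compounds below may be only part of what the source reports. "The series", "measured", "known", "first", "only" and "open" are said of these compounds alone.

In an ADME assay on microsomes from liver (Homo sapiens) for metabolic stability (on this read-out lower numbers stand for a shorter-lived compound and higher numbers for a longer-lived compound), compound 2 `COc1ccn2c(-c3ccc(NC(=O)c4ccc([N+](=O)[O-])o4)cc3C)cnc2c1` gives 0.717 h, the higher of the two numbers recorded so far. Compound 1 `O=C(Nc1ccc(-c2cnc3ccccn23)cc1)c1ccc([N+](=O)[O-])o1` gives 0.412 h, and the two values lie within the usual scatter of each other, so no order between them can be claimed. Compound 3 `Cc1cc(NC(=O)c2ccc([N+](=O)[O-])o2)ccc1-c1cnc2ccccn12` has not yet been measured in this assay. It differs from compound 2 in one place: hydrogen in place of methoxy on an aromatic carbon. Within the data shown here, no pair of measured compounds shows what this change does, so no step beyond the scatter is expected in either direction. Compound 3 is therefore estimated at 0.55 h, within a range from 0.25 h to 1.2 h. The expected step is a 1.3-fold lower number from compound 2 to compound 3 (0.12 log units; within the scatter).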

Compound 3, half-life: 0.687 h
Estimate against measurement, compound 3: 1.2-fold (0.10 log units) below; the measured number falls inside the stated range.
By their numbers in this assay, from the lowest: compounds 1, 3 and 2 (each within the scatter of the next).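

In this assay, hydrogen in place of methoxy on this aromatic carbon, opposite the ring nitrogen, gives a 1.0-fold lower number from compound 2 to compound 3 (0.02 log units; within the scatter) and so leaves no readable change in half-life. Methyl in place of hydrogen on an aromatic carbon gives a 1.7-fold higher number from compound 1 to compound 3 (0.22 log units; within the scatter) and also stays within the scatter. Nothing measured here offers an explanation for either result. Still open, as far as these compounds go, is whether an amine or a longer chain such as butoxy at the methoxy position would move the half-life beyond the scatter. From the compounds shown here alone, whether methoxy behaves the same way on other cores also remains unknown.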